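Replacing 3,5-dichlorophenyl with 5-methylpyridin-2-yl

This account rests on a few compounds, and the source may have more. Where it says the series, first, only, none or still open, it means among the compounds named here.

Compound 1 `O=C(NC[C@@H]1[C@H]2CN(C(=O)OCc3cc(Cl)cc(Cl)c3)C[C@@H]12)c1ccc2[nH]c(=O)oc2c1`: 137 10^-6 cm/s
Compound 2 `O=C(NC[C@@H]1[C@H]2CN(C(=O)OCc3cc(C(F)(F)F)cc(C(F)(F)F)c3)C[C@@H]12)c1ccc2[nH]c(=O)oc2c1`: 108 10^-6 cm/s

In an ADME assay on Caco-2 cells (Homo sapiens) for permeability, in the apical to basolateral direction, with a stated time of 90 min, tested at 10 uM (a lower number here means that the compound crosses the layer more slowly, a higher number that the compound crosses the layer faster), compound 1 gives 137 10^-6 cm/s, and this stands within the usual scatter of compound 2 at 108 10^-6 cm/s. Going by the values given here, the two values therefore set no order between these compounds. Compound 3 `Cc1ccc(COC(=O)N2C[C@@H]3[C@@H](CNC(=O)c4ccc5[nH]c(=O)oc5c4)[C@@H]3C2)nc1` has not yet been measured. It differs from compound 1 as follows: 5-methylpyridin-2-yl in place of 3,5-dichlorophenyl on a saturated chain carbon bound to an oxygen next to a carbonyl group. In words, 5-methylpyridin-2-yl takes the place of 3,5-dichlorophenyl on a saturated chain carbon bound to an oxygen next to a carbonyl group. Among the compounds with values here, no measured pair differs in one place only, so the data give no direct precedent for this change. The expected result in this assay is a fall slightly beyond the scatter, and this judgement is correspondingly uncertain. The estimated step is a 2.1-fold lower number from compound 1 to compound 3 (0.32 log units; beyond the scatter). For compound 3, the estimated value is 65 10^-6 cm/s, with an expected range of 25 10^-6 cm/s to 125 10^-6 cm/s.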

Compound 3, apparent permeability: 1 10^-6 cm/s
Estimate against measurement, compound 3: 65-fold (1.81 log units) above; measured number outside the range, below it.
By their numbers in this assay, from the lowest: compound 3; then compounds 2 and 1 (each within the scatter of the next).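

In this assay, the group on a saturated chain carbon bound to an oxygen next to a carbonyl group turns out to matter greatly: the change shows a 140-fold lower number from compound 1 to compound 3 (2.14 log units; beyond the scatter) when 5-methylpyridin-2-yl takes the place of 3,5-dichlorophenyl. Compound 1 and compound 2 stand within the usual scatter of each other and gave no sign of such sensitivity at this position, so a single change here can produce a large step. Nothing among the data shown accounts for the size of this step.

The compounds shown leave open whether the step follows the ring nitrogen, the methyl or the loss of the chlorine atoms, all of which change together here. A plain phenyl ring, or a pyridine ring carrying chlorine in place of the methyl, would separate these contributions.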